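The compounds below may be only part of what the source reports. "The series", "measured", "known", "first", "only" and "open" are said of these compounds alone.

Measured so far in a functional assay on B16-F10 cells (Mus musculus) for cytotoxicity, read by MTT assay, with a stated time of 48 h; a lower number here means a stronger inhibitor, a higher number a weaker inhibitor:
- compound 1 `COc1ccc(N/C=C\C(=O)c2nc(-c3ccc(C(F)(F)F)cc3)n3ccccc23)cc1OC` gives only a limit, > 30000 nM
- compound 2 `O=C(/C=C\Nc1cnc2ccccc2c1)c1nc(-c2ccccc2)n2ccccc12` gives 3780 nM
- compound 3 `O=C(/C=C\Nc1ccc(F)cc1)c1nc(-c2ccc(C(F)(F)F)cc2)n2ccccc12` gives only a limit, > 30000 nM

Compound 3 therefore stands at the limit in this assay, not at a number, and of the values shown it shares that place with compound 1. Compound 4 `O=C(/C=C\Nc1cnc2ccccc2c1)c1nc(-c2ccc(C(F)(F)F)cc2)n2ccccc12` differs from compound 3 by quinolin-3-yl in place of 4-fluorophenyl on an amine nitrogen. Among the compounds with values here, no measured step covers this change. Within the data shown here, the one measured step, a step that the two limits leave unreadable from compound 1 to compound 3, runs between two limits and is unreadable because both sit at the limit of > 30000 nM in this assay, at which 2 of the 3 values shown sit. Compound 2, carrying the same quinolin-3-yl group on a different core, gives 3780 nM. From this compound 4 is expected to reach 12000 nM, estimated between 3000 nM and 40000 nM, the expected step of an at least 2.5-fold lower number from compound 3 to compound 4 (0.39 log units; beyond the scatter) pointing toward stronger inhibition, with the size uncertain.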

Compound 4, half-maximal inhibitory concentration: > 30000 nM
Compound 4: a limit, no number (the forecaster's own chance of this, stated with the estimate: 45%); middle value at least 2.5-fold (0.39 log units) away from the limit.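

In this assay, quinolin-3-yl on the amine nitrogen does not by itself secure a measurable value: trifluoromethyl in place of hydrogen on an aromatic carbon gives an at least 7.9-fold higher number from compound 2 to compound 4 (0.89 log units; beyond the scatter), and compound 4 reaches only a limit of the assay. The steps to compound 4 from compound 1 and compound 3 cannot be read because all three compounds sit at the same limit: the limit of > 30000 nM in this assay, at which 3 of the 4 values shown sit.

As far as these compounds go, it remains open how 4-fluorophenyl or 3,4-dimethoxyphenyl on the amine nitrogen would read without the trifluoromethyl. From the compounds shown here alone, it is also open whether a methoxy group or a chlorine atom in its place would give a number rather than a limit.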